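Replacing a Cyclopropyl Amine by a Bromophenyl Amine

A few compounds are considered here, and "the series" means these few. Any claim that something is new, unique, unknown or untested is made for them only; others in the source may bear on it.

Compound 1 `O=c1cc(NC2CC2)cc(-c2ccccc2)o1` carries a cyclopropyl group on the ring nitrogen and a phenyl group on its core. In a functional assay on KB cells (Homo sapiens) for cytotoxicity, read by MTT assay, with a stated time of 72 h (on this read-out lower numbers stand for an effect already at smaller amounts and higher numbers for an effect only at larger amounts of compound), compound 1 reaches only the assay limit of > 30 uM, so no number is known for it. Two related compounds with an aromatic group on the same nitrogen fare differently: compound 2 `COc1ccc(Nc2cc(/C=C/c3ccccc3)oc(=O)c2)cc1` gives 0.15 uM and compound 3 `COc1ccc(Nc2cc(-c3ccc4ccccc4c3)oc(=O)c2)cc1` gives 0.18 uM in this assay, values that sit within the usual scatter of each other. Compound 4 `O=c1cc(Nc2ccc(Br)cc2)cc(-c2ccccc2)o1` changes compound 1 as described by 4-bromophenyl in place of cyclopropyl on a nitrogen on an aromatic ring, bringing in 4-bromophenyl in place of cyclopropyl on a nitrogen on an aromatic ring. A step toward smaller amounts is expected from compound 1 to compound 4, of size an at least 10-fold lower number from compound 1 to compound 4 (1.00 log units; beyond the scatter). Compound 4 is expected to give 3 uM, between 0.5 uM and 20 uM.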

Compound 4, concentration for half-maximal effect: 0.32 uM
The estimate for compound 4 lay 9.4-fold (0.97 log units) above the measured number; measured number below the stated range.
By their numbers in this assay, from the lowest: compounds 2, 3 and 4 (each within the scatter of the next, the first and the last beyond it). At a limit, above all of these: compound 1.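

The nitrogen group alone separates the two compounds on this core: 4-bromophenyl in place of cyclopropyl gives an at least 93-fold lower number from compound 1 to compound 4 (1.97 log units; beyond the scatter) in this assay. This is the only pair shown that differs in one place, so it ties an aromatic ring on this nitrogen directly to a lower number. The true size of the step stays unknown, since one end of it is an assay limit: the limit of > 30 uM in this assay, at which 1 of the 4 values shown sits.

From the compounds shown here alone, it remains open whether the ring alone or also its bromine accounts for the step, which a plain phenyl on this nitrogen could separate. Going by these compounds, how a longer alkyl chain or a carboxylic acid in place of the bromine would fare also stays open.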